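Intrinsic activity series: ethoxy in place of ethyl

The compounds below may be only part of what the source reports. "The series", "measured", "known", "first", "only" and "open" are said of these compounds alone.

Measured compounds:
- compound 1, `CC(Oc1ccccc1C=O)C1=NCCN1`: 0.6
- compound 2, `CCc1ccccc1OC(C)C1=NCCN1`: 0.6

In an assay on CHO cells with Alpha-2C adrenergic receptor (Homo sapiens) as the target (a higher number here means a larger maximal response, a lower number a smaller maximal response), compound 1 gives 0.6 and compound 2 gives 0.6. For the measured compounds named here, the one measured step, no change at the digits printed from compound 1 to compound 2 (within the scatter), swapped ethyl in place of formyl on an aromatic carbon and left the read-out where it was. Compound 2 thus stands level with compound 1 within the scatter; there is no ordering between the two.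

Compound 3, `CCOc1ccccc1OC(C)C1=NCCN1`, has not been measured in this assay. Its change from compound 2 is ethoxy in place of ethyl on an aromatic carbon. Going by the values given here, no measured step bears directly on an ethoxy entering at that aromatic carbon; the only step available, no change at the digits printed from compound 1 to compound 2 (within the scatter), concerned a different group at the same kind of position and showed no movement. On that evidence alone the expectation is no step beyond the scatter, that is no change at the digits printed from compound 2 to compound 3 (within the scatter). Compound 3 is therefore estimated at 0.6, in the range 0.4 to 0.8.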

Compound 3, intrinsic activity: the largest response reached, as a fraction of the reference agonist's: 0.45
Estimate against measurement, compound 3: 0.15 above, and the stated range covers the measured number.
By their numbers in this assay, from the lowest: compound 3; then compounds 1 and 2 (each within the scatter of the next).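

In this assay ethoxy in place of ethyl on the aromatic carbon gives a number 0.15 lower from compound 2 to compound 3 (beyond the scatter) and ethoxy in place of formyl at the same carbon gives a number 0.15 lower from compound 1 to compound 3 (beyond the scatter), so the group at this position can move the maximal response. The earlier pair, with no change at the digits printed from compound 1 to compound 2 (within the scatter), gave no sign of this. Of the three groups, only ethoxy stands apart, while formyl and ethyl remain level with each other within the scatter.

As far as these compounds go, whether a longer chain such as propoxy, or an amine or a hydroxyl at this carbon, would lower the maximal response further or bring it back remains open. Nothing at hand accounts for the lower number with ethoxy.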